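The source may report more compounds than this note shows. Statements on the series, on what has been measured and on what is new or still open speak of the compounds shown alone.

Values measured in a functional assay on HeLa cells (Homo sapiens) for inhibition, read by CCK-8 assay, with a stated time of 48 h (a higher number here means a weaker inhibitor, a lower number a stronger inhibitor), are as follows.

Compound 1 `COc1cc(-c2ccnc3cc(-c4ccc(F)cc4)nn23)cc(OC)c1OC` gives 5840 nM
Compound 2 `COc1cc(-c2ccnc3cc(-c4ccc5cc[nH]c5c4)nn23)cc(OC)c1OC` gives 125 nM
Compound 3 `COc1cc(-c2ccnc3cc(-c4ccc(C(F)(F)F)cc4)nn23)cc(OC)c1OC` gives 1840 nM

Compound 3 holds the second highest of the three numbers, with a 3.2-fold lower number from compound 1 to compound 3 (0.50 log units; beyond the scatter) and a 15-fold higher number from compound 2 to compound 3 (1.17 log units; beyond the scatter) as the steps leading to it. Compound 4 `COc1cc(-c2ccnc3cc(-c4ccc5cnn(C)c5c4)nn23)cc(OC)c1OC` changes one group of compound 3 and keeps the shared core: 1-methyl-1H-indazol-6-yl in place of 4-(trifluoromethyl)phenyl on an aromatic carbon with 1-methyl-1H-indazol-6-yl entering in place of 4-(trifluoromethyl)phenyl on an aromatic carbon.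

Among the compounds with values here, compound 2 is the only measured compound with two rings in the group at this place, so its 1H-indol-6-yl is the nearest guide to the entering group. Within the data shown here, the steps that bear on the change are large, namely a 47-fold lower number from compound 1 to compound 2 (1.67 log units; beyond the scatter) and a 15-fold higher number from compound 2 to compound 3 (1.17 log units; beyond the scatter) in the same read-out. The step between the two single-ring groups is only modest, at a 3.2-fold lower number from compound 1 to compound 3 (0.50 log units; beyond the scatter) as measured. Among the measured compounds shown here, no measured compound shows what the methyl group and the second ring nitrogen do to the value of compound 2. A large step towards a lower number in this assay is therefore expected, though somewhat smaller than the gap that compound 2 shows. The estimated step is a 6.1-fold lower number from compound 3 to compound 4 (0.79 log units; beyond the scatter) in this expectation. For compound 4 the estimated value is 300 nM with an expected range from 90 nM to 1000 nM in this assay.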

Compound 4, half-maximal inhibitory concentration: 97 nM
Beside the measured number, compound 4's estimate is 3.1-fold (0.49 log units) above it; low and high end bracket the measured number.
By their numbers in this assay, from the lowest: compounds 4 and 2 (each within the scatter of the next); then compound 3; then compound 1.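

In this assay, a 19-fold lower number from compound 3 to compound 4 (1.28 log units; beyond the scatter) and a 60-fold lower number from compound 1 to compound 4 (1.78 log units; beyond the scatter) show that 1H-indol-6-yl is not the only two-ring group at this place that stands well apart from the single-ring groups; among these four compounds, both two-ring groups give lower numbers than both single-ring groups, and none goes against this. With a 1.3-fold lower number from compound 2 to compound 4 (0.11 log units; within the scatter), which lies within the scatter, the two two-ring groups cannot be told apart in this read-out, so the hydrogen on the ring nitrogen of 1H-indol-6-yl is not required to reach this range, since 1-methyl-1H-indazol-6-yl has no hydrogen-bond donors. The data shown offer no measurement that would account for these differences.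

The compounds shown leave open what happens when the methyl group of 1-methyl-1H-indazol-6-yl gives way to a longer chain, or when an amine or a carboxylic acid is carried on the two-ring group at this place. They also leave open whether a hydroxyl group could stand in for a methoxy group on the shared core without losing the values seen with the two-ring groups.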